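This account rests on a few compounds, and the source may have more. Where it says the series, first, only, none or still open, it means among the compounds named here.

In a functional assay on CHO cells for antagonist activity at Orexin receptor type 2 (Homo sapiens), read by FLIPR and calcium flux (on this read-out higher numbers stand for weaker inhibition and lower numbers for stronger inhibition), two compounds have been measured so far. Compound 1 `CCc1nc(C(C)C)c2n1CCN([C@@H](C(=O)NC)c1ccccc1)C2CCc1ccc(C(F)(F)F)cc1` gives 2900 nM. Within the data shown here, compound 2 `CCc1nc(I)c2n1CCN([C@@H](C(=O)NC)c1ccccc1)C2CCc1ccc(C(F)(F)F)cc1` gives 23 nM, the lowest of the two numbers; its nearest neighbour is compound 1, and the single step of a 130-fold lower number from compound 1 to compound 2 (2.10 log units; beyond the scatter) shows how much hinges on the group at this one aromatic carbon. Compound 3 `CCc1nc(OC)c2n1CCN([C@@H](C(=O)NC)c1ccccc1)C2CCc1ccc(C(F)(F)F)cc1` has not yet been measured; it differs from compound 2 by methoxy in place of iodo on an aromatic carbon, the position being that on the five-membered aromatic ring with two nitrogens, two ring bonds from the ring atom that bears the ethyl group.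

Among the measured compounds shown here, no measured step exchanges iodo for methoxy, so the only guide is the large step from compound 1 to compound 2, which tells that this position tolerates change poorly in one direction. For compound 3 the expectation is therefore a step of a 6.5-fold higher number from compound 2 to compound 3 (0.81 log units; beyond the scatter), a loss in this assay, with room for a small or a much larger change. Compound 3 is expected to give about 150 nM, estimated between 30 nM and 800 nM.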

Compound 3, half-maximal inhibitory concentration: 73 nM
For compound 3 the middle estimate is 2.1-fold (0.31 log units) above the measured one; low and high end bracket the measured number.
By their numbers in this assay, from the lowest: compound 2; then compound 3; then compound 1.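

Methoxy in place of iodo gives a 3.2-fold higher number from compound 2 to compound 3 (0.50 log units; beyond the scatter) in this assay, a modest step, whereas methoxy in place of isopropyl gives a 40-fold lower number from compound 1 to compound 3 (1.60 log units; beyond the scatter), a large one. Among these compounds, the earlier pair showed only that the two groups at this aromatic carbon stood far apart, and methoxy now adds a third point that lies much closer to iodo than to isopropyl, so not every replacement of iodo here carries a loss on the scale of the one seen with isopropyl. It also shows that a group bringing an oxygen and one hydrogen-bond acceptor to this carbon keeps the number well below that of compound 1, although no measurement at hand explains the order of the three groups.

With only three groups at this carbon, the compounds shown cannot separate the part played by the oxygen from that of the group's shape or size. Going by these compounds, how an amine, a chlorine, a nitrile or a longer chain such as ethoxy would fall relative to iodo, methoxy and isopropyl remains open.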